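A few compounds are considered here, and "the series" means these few. Any claim that something is new, unique, unknown or untested is made for them only; others in the source may bear on it.

Measured compounds in a functional assay on NCI-H226 cells (Homo sapiens) for inhibition, read by sulforhodamine B assay, with a stated time of 48 h, tested at 10 uM; on this read-out higher numbers stand for more inhibition at the one concentration tested (going by the name of the read-out) and lower numbers for less inhibition:
compound 1, `Brc1cn2ccnc2c(-c2ccc3ncn(C4CCCCC4)c3c2)n1`, gives 22.5%;
compound 2, `O=Cc1ccc(-c2cn3ccnc3c(-c3ccc4ncn(C5CCCCC5)c4c3)n2)cc1`, gives 0.53%;
compound 3, `Clc1ccc(-c2cn3ccnc3c(-c3ccc4ncn(C5CCCCC5)c4c3)n2)cc1`, gives 19.4%.

Compound 3 stands second highest of the three numbers. Its nearest neighbour is compound 1, with a number 3.1 percentage points lower from compound 1 to compound 3 (within the scatter), and its furthest is compound 2, with a number 18.9 percentage points higher from compound 2 to compound 3 (beyond the scatter). The change of 4-chlorophenyl for bromo on an aromatic carbon thus left the read-out where it was, while the change of chloro for formyl on an aromatic carbon raised it beyond the scatter.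

Compound 4, `c1csc(-c2cn3ccnc3c(-c3ccc4ncn(C5CCCCC5)c4c3)n2)c1`, has not yet been measured. It differs from compound 3 in one place: thiophen-2-yl in place of 4-chlorophenyl on an aromatic carbon. Among the measured compounds shown here, the steps that bear on it are those at the same aromatic carbon, a number 22 percentage points lower from compound 1 to compound 2 (beyond the scatter) and a number 3.1 percentage points lower from compound 1 to compound 3 (within the scatter); they show that the group at this position can move the read-out modestly or not at all. With a small aromatic group entering, a step within the scatter is expected, a number 4.4 percentage points lower from compound 3 to compound 4 (within the scatter). Compound 4 is therefore estimated at 15%, in a range from 0% to 32%.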

Compound 4, a percentage reported as inhibition, at one concentration (the size of the read-out at that concentration, not a potency): 17.1%
Beside the measured number, compound 4's estimate is 2.1 percentage points below it; measured number inside the range.
By their numbers in this assay, from the lowest: compound 2; then compounds 4, 3 and 1 (each within the scatter of the next).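

In this assay, thiophen-2-yl, with its five-membered ring and sulfur, behaves much like the larger 4-chlorophenyl, with a number 2.3 percentage points lower from compound 3 to compound 4 (within the scatter), and like the bromo group, with a number 5.4 percentage points lower from compound 1 to compound 4 (within the scatter). Only the 4-formylphenyl group stands apart, with a number 16.6 percentage points higher from compound 2 to compound 4 (beyond the scatter), so among these four compounds an aromatic ring at this carbon does not by itself bring the low number, and compound 2 is the one exception to the otherwise level read-out. No evidence is available to explain why compound 2 differs.

Going by these compounds, it remains open whether an amine or a carboxylic acid on the phenyl ring would track with formyl or with chloro. Also open, on these data alone, is how a longer chain at this carbon would compare with the aromatic groups on the shared core.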